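Propyl in Place of Chloro on a Shared Core

The source may report more compounds than this note shows. Statements on the series, on what has been measured and on what is new or still open speak of the compounds shown alone.

Compound 1 `Cc1cc(Cl)c(S(C)(=O)=O)cc1C(=O)N=C(N)N` gives 25 nM in a functional assay for inhibition of sodium/hydrogen exchanger (Oryctolagus cuniculus) (on this read-out higher numbers stand for weaker inhibition and lower numbers for stronger inhibition), and compound 2 `Cc1c(C(=O)N=C(N)N)cc(S(C)(=O)=O)c(Cl)c1Cl` gives 29 nM in this assay; the two sit within the scatter of each other. Among the measured compounds shown here, the only measured step, a 1.2-fold higher number from compound 1 to compound 2 (0.06 log units; within the scatter), concerns a chloro entering at a different place on the core. Compound 3 `CCCc1cc(C)c(C(=O)N=C(N)N)cc1S(C)(=O)=O` differs from compound 1 by propyl in place of chloro on an aromatic carbon. For the measured compounds named here, no measured step touches the carbon where the propyl enters, so the known data give little guidance on this change. Compound 3 is expected to show a 1.3-fold lower number from compound 1 to compound 3 (0.10 log units; within the scatter), with an estimated value of 20 nM and a range from 6 nM to 70 nM.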

Compound 3, half-maximal inhibitory concentration: 5.7 nM
Compound 3: middle estimate off by 3.5-fold (0.55 log units), on the high side, and the stated range ends above it.
By their numbers in this assay, from the lowest: compound 3; then compounds 1 and 2 (each within the scatter of the next).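

On this aromatic carbon, ortho to a methylsulfonyl group, propyl in place of chloro brings a 4.4-fold lower number from compound 1 to compound 3 (0.64 log units; beyond the scatter) and so stronger inhibition in this assay on the shared core. This is the first change shown to move the number beyond the scatter, and it shows that this carbon carries propyl without loss. Nothing available bears on why this swap has this effect.

On these data alone, whether ethyl, butyl or an amine on this carbon would give a lower or higher number remains open. So does whether propyl would have the same effect on the core of compound 2.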